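The source may hold more compounds than are shown below. What is called first, only, known or untested is meant among the compounds shown, and "the series" means these compounds.

Measured in a functional assay on A549 cells (Homo sapiens) for cytotoxicity, read by MTT assay, with a stated time of 72 h; a higher number here means a weaker inhibitor, a lower number a stronger inhibitor
compound 1 `O=C1c2c[n+]([O-])c3ccccc3c2C(=O)c2c1c1ccccc1n2CCCCN1CCNCC1` gives 540 nM
compound 2 `CCCCN1CCN(CCCCn2c3c(c4ccccc42)C(=O)c2c[n+]([O-])c4ccccc4c2C3=O)CC1` gives 550 nM

Compound 2 stands level with compound 1, the two values lying within the scatter. Compound 3 `CN1CCN(CCCCCCn2c3c(c4ccccc42)C(=O)c2c[n+]([O-])c4ccccc4c2C3=O)CC1` is unmeasured and differs from compound 2 by 2-(4-methylpiperazin-1-yl)ethyl in place of 4-butylpiperazin-1-yl on a saturated chain carbon, four bonds along the chain from an aromatic nitrogen on a saturated chain carbon, four bonds along the chain from an aromatic nitrogen. Going by the values given here, the only measured step puts butyl in place of hydrogen on an amine nitrogen in a ring. Among the compounds with values here, since a 1.0-fold higher number from compound 1 to compound 2 (0.01 log units; within the scatter) is that sole guide and no measured pair varies the chain, no shift beyond the scatter is expected in this assay and no direction is favoured. The estimate means a 1.1-fold lower number from compound 2 to compound 3 (0.04 log units; within the scatter) as an expected step. Compound 3 is estimated at 500 nM within a range from 200 nM to 1250 nM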

Compound 3, half-maximal inhibitory concentration: 330 nM
Estimate against measurement, compound 3: 1.5-fold (0.18 log units) above, and the stated range covers the measured number.
By their numbers in this assay, from the lowest: compounds 3, 1 and 2 (each within the scatter of the next).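

In this assay, 2-(4-methylpiperazin-1-yl)ethyl in place of 4-butylpiperazin-1-yl on the saturated chain carbon gives a 1.7-fold lower number from compound 2 to compound 3 (0.22 log units; within the scatter), and in place of piperazin-1-yl it gives a 1.6-fold lower number from compound 1 to compound 3 (0.21 log units; within the scatter). This position therefore accepts a change to the chain together with a change on the ring nitrogen, and all three compounds remain level. No evidence on the cause of these values is available.

The chain and the ring substituent change together in compound 3, so neither can be read alone. As far as these compounds go, whether a longer chain, or a morpholine in place of the piperazine, would move the number beyond the scatter remains open.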